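Two difluorophenyl isomers on the aminothiophene core

The source may report more compounds than this note shows. Statements on the series, on what has been measured and on what is new or still open speak of the compounds shown alone.

Compound 1 `CC(C)(C)Cc1c(-c2ccncc2)sc(N)c1C(=O)c1ccc(Cl)cc1` carries a pyridin-4-yl group on the shared core; in an assay on CHO cells for displacement of a labelled ligand from adenosine receptor A3 (Homo sapiens), read by scintillation counting, tested at 10 uM (on this read-out higher numbers stand for more inhibition at the one concentration tested (going by the name of the read-out) and lower numbers for less inhibition), compound 1 gives 6%. Compound 2 `CC(C)(C)Cc1c(-c2cccc(F)c2F)sc(N)c1C(=O)c1ccc(Cl)cc1` puts a 2,3-difluorophenyl group in that place and in this assay compound 2 gives 1%. Within the data shown here, the one step measured so far, a number 5 percentage points lower from compound 1 to compound 2 (within the scatter), is therefore within the scatter. Among the two numbers compound 2 has the lowest, with compound 1 as its nearest neighbour, though the two cannot be ordered on these data.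

Compound 3 `CC(C)(C)Cc1c(-c2ccc(F)cc2F)sc(N)c1C(=O)c1ccc(Cl)cc1` is the next compound, differing from compound 2 only in the arrangement of the same atoms: 2,4-difluorophenyl in place of 2,3-difluorophenyl on an aromatic carbon. Among the measured compounds shown here, no measured step concerns the move of a fluorine within the ring; the only step available, a number 5 percentage points lower from compound 1 to compound 2 (within the scatter), swaps one aryl group for another and is itself within the scatter. Both measured numbers are small, so no step beyond the scatter is expected here. For compound 3 the estimated value in this assay is 3%, with a range from -8% to 14%. The expected step is a number 2 percentage points higher from compound 2 to compound 3 (within the scatter), which is within the scatter.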

Compound 3, a percentage reported as inhibition, at one concentration (the size of the read-out at that concentration, not a potency): 1%
Beside the measured number, compound 3's estimate is 2 percentage points above it; the measured number falls inside the stated range.
By their numbers in this assay, from the lowest: compounds 2, 3 and 1 (each within the scatter of the next).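

Moving one fluorine, with 2,4-difluorophenyl in place of 2,3-difluorophenyl on the aromatic carbon next to the ring sulfur, gives no change at the digits printed from compound 2 to compound 3 (within the scatter) in this assay and so provides the first reading of a fluorine shift at this position: these two arrangements cannot be told apart. The exchange of pyridin-4-yl for this second difluorophenyl isomer gives a number 5 percentage points lower from compound 1 to compound 3 (within the scatter) and, like the step to the 2,3-difluorophenyl isomer, stays inside the scatter, so the three aryl groups at this position cannot be ordered on these numbers. No accompanying measurement bears on this flat result.

Going by these compounds, whether any group at this position can lift the number clear of the scatter remains open, for instance a piperidin-4-yl group, which carries an amine, or a phenyl ring bearing a carboxylic acid. On these data alone, the neopentyl and (4-chlorophenyl)carbonyl groups are the same in all three compounds, so it is also open whether a shorter chain such as ethyl in place of neopentyl would change the reading.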